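Replacing the amino-linked aryl on the carbonyl of compound 2

The source may hold more compounds than are shown below. What is called first, only, known or untested is meant among the compounds shown, and "the series" means these compounds.

Measured compounds:
compound 1, `O=C(Nc1cccc(-n2cc(-c3ccncc3)c(-c3cc(O)cc(Cl)c3)n2)c1)Nc1ccc(Cl)c(C(F)(F)F)c1`, -10%
compound 2, `COc1cc(Cl)cc(-c2nn(-c3cccc(NC(=O)Nc4ccc(Cl)c(C(F)(F)F)c4)c3)cc2-c2ccncc2)c1`, -16%
compound 3, `COc1cc(Cl)cc(-c2nn(-c3cccc(NC(=O)Nc4cc(C(F)(F)F)cc(C(F)(F)F)c4)c3)cc2-c2ccncc2)c1`, -22%

In a functional assay on OVCAR-4 cells (Homo sapiens) for inhibition, read by sulforhodamine B assay, with a stated time of 48 h, tested at 100 uM (a higher number here means a weaker effect of the compound at the concentration tested, a lower number a stronger effect), compound 1 gives -10%, compound 2 gives -16% and compound 3 gives -22%. Compound 2 stands second highest of the three numbers; its nearest neighbour is compound 1, its furthest compound 3, and both gaps lie within the scatter. Among the measured compounds shown here, the only step between measured compounds that differ in one place is a number 6 percentage points lower from compound 1 to compound 2 (within the scatter), which is within the scatter and concerns the oxygen on an aromatic ring, a different part of the shared core.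

Compound 4, `COc1cc(Cl)cc(-c2nn(-c3cccc(NC(=O)c4cccc(C(F)(F)F)c4)c3)cc2-c2ccncc2)c1`, is not yet measured. It differs from compound 2 in that (3-(trifluoromethyl)phenyl in place of (4-chloro-3-(trifluoromethyl)phenyl)amino on a carbonyl carbon). For the measured compounds named here, no measured step bears on this change, so nothing beyond the values of compounds 1, 2 and 3 can guide an expectation. Those values all show little effect at the tested concentration, and the change in compound 4 is expected to leave the read-out within the scatter, with a number 6 percentage points higher from compound 2 to compound 4 (within the scatter). Compound 4 is therefore estimated at -10%, between -30% and 12%.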

Compound 4, a percentage reported as activity, at one concentration (the size of the read-out at that concentration, not a potency): 74%
Compound 4: the middle estimate sits 84 percentage points below what was measured; the whole stated range lies below it.
By their numbers in this assay, from the lowest: compounds 3, 2 and 1 (each within the scatter of the next, the first and the last beyond it); then compound 4.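

In this assay, among the compounds shown here, the group on the carbonyl carbon is the first place in these compounds where a single change moves the read-out far, with a number 90 percentage points higher from compound 2 to compound 4 (beyond the scatter) and thus a much weaker effect at the concentration tested, whereas the earlier step at the oxygen on the aromatic ring stayed within the scatter. The effect seen for compound 2 therefore depends on what sits on this carbonyl carbon, which here is the whole (4-chloro-3-(trifluoromethyl)phenyl)amino group, with 1 hydrogen-bond donor, against 3-(trifluoromethyl)phenyl, with 0 hydrogen-bond donors. Nothing available explains why the read-out moves so far with this change.

On these data alone, the amino link and the chlorine leave together in this one step, so how much of the change belongs to each remains open, and (3-(trifluoromethyl)phenyl)amino on the same carbonyl carbon would separate the two. Also open is how a saturated group such as cyclohexyl or cyclohexylamino would read at this place, since every group shown on this carbonyl carbon carries an aromatic ring of carbon only.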